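The source may report more compounds than this note shows. Statements on the series, on what has been measured and on what is new or still open speak of the compounds shown alone.

Measured compounds and their values in a functional assay on SK-MEL-28 cells (Homo sapiens) for inhibition, read by sulforhodamine B assay, with a stated time of 48 h; a lower number here means that less compound is tolerated, a higher number that more compound is tolerated:
- compound 1 `Nc1cc(N)c2nc(-c3ccccc3)c(Oc3ccc(Cl)c(Cl)c3)nc2c1` — < 100000 nM
- compound 2 `COc1ccc(Sc2nc3cc(N)cc(N)c3nc2-c2ccccc2)cc1` — < 100000 nM

Compound 1 gives only a limit of this assay, < 100000 nM, not a number. Compound 2 likewise gives only a limit, < 100000 nM. Where compound 2 stands on the numbers can therefore not be pinned down: both values shown sit at the same limit, (the limit of < 100000 nM in this assay, at which 2 of the 2 values shown sit), and the one step between them, a step that the two limits leave unreadable from compound 1 to compound 2, cannot be read.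

Compound 3 `Nc1cc(N)c2nc(-c3ccccc3)c(Sc3ccc(Cl)c(Cl)c3)nc2c1` is the unmeasured member. It differs from compound 2 by 3,4-dichlorophenyl in place of 4-methoxyphenyl on a sulfur. For the measured compounds named here, compound 3 carries the sulfur of compound 2 together with the 3,4-dichlorophenyl ring of compound 1, so the one measured step bears on it directly, yet that step is of unreadable size because a step that the two limits leave unreadable from compound 1 to compound 2 is bounded on both sides by the limit. No direction and no size beyond the scatter can be claimed for the change from compound 2 to compound 3; all that the two limits support is that a value past the limit is unlikely. Compound 3 is therefore expected to give roughly 30000 nM, with a range from 5000 nM to 100000 nM. The step this estimate implies, a step that the limit leaves unreadable from compound 2 to compound 3, is nominal, since compound 2 itself is known only as a limit.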

Compound 3, concentration lethal to 50% of the cells: < 100000 nM
Compound 3: no number, only a limit; the forecaster's own chance of this, stated with the estimate: 40%; the middle value does not contradict the limit.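

In this assay compound 3 gives < 100000 nM as a limit, not a number. For the compounds shown here, no step among compound 1, compound 2 and compound 3 can be read, since all of them sit at one limit: the limit of < 100000 nM in this assay, at which 3 of the 3 values shown sit. The compounds shown leave open whether 3,4-dichlorophenyl in place of 4-methoxyphenyl, or (3,4-dichlorophenyl)sulfanyl in place of 3,4-dichlorophenoxy, changes the read-out at all.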